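This account rests on a few compounds, and the source may have more. Where it says the series, first, only, none or still open, it means among the compounds named here.

Compound 2 `C[C@H](CCCNC(C)(C)C)Nc1ccnc2cc(Cl)ccc12` gives 170000 nM in an assay for binding affinity, read by spectrophotometry; on this read-out higher numbers stand for weaker inhibition and lower numbers for stronger inhibition. Among the two numbers in hand it holds the lowest, though its only neighbour, compound 1 `C[C@H](CCCN(C)C)Nc1ccnc2cc(Cl)ccc12`, gives 190000 nM in this assay, and the gap between the two is within the scatter, so no order between them can be read. Among the compounds with values here, the one step so far, a 1.1-fold lower number from compound 1 to compound 2 (0.05 log units; within the scatter), touches exactly the position that is about to change again: the amine substituent at the end of the saturated chain. That step stayed flat.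

Compound 3 `CCN(C)CCC[C@@H](C)Nc1ccnc2cc(Cl)ccc12` carries ethyl(methyl)amino in place of (tert-butyl)amino on a saturated chain carbon, four bonds along the chain from a nitrogen on an aromatic ring. Ethyl(methyl)amino sits, in size and in the counted donors and acceptors, between the dimethylamino of compound 1 and the (tert-butyl)amino of compound 2. Both of those gave numbers that lie within the scatter of each other, so nothing in the series points to a move beyond the scatter for this assay in either direction. The expected step is therefore a 1.1-fold higher number from compound 2 to compound 3 (0.02 log units; within the scatter), essentially none. For compound 3 the estimate in this assay is 180000 nM, with a range from 100000 nM to 330000 nM.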

Compound 3, half-maximal inhibitory concentration: 140000 nM
Compound 3: the middle estimate sits 1.3-fold (0.11 log units) above what was measured; measured number inside the range.
By their numbers in this assay, from the lowest: compounds 3, 2 and 1 (each within the scatter of the next).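

Read in this assay, the change from (tert-butyl)amino with 1 hydrogen-bond donor to ethyl(methyl)amino with 0 hydrogen-bond donors, 5 heavy atoms giving way to 4, stays flat (a 1.2-fold lower number from compound 2 to compound 3 (0.08 log units; within the scatter)). The smaller change at the same end of the chain, methyl in place of hydrogen on a saturated chain carbon bound to an amine nitrogen, stays flat as well (a 1.4-fold lower number from compound 1 to compound 3 (0.13 log units; within the scatter)), so dimethylamino, ethyl(methyl)amino and (tert-butyl)amino cannot be told apart at this place, on a saturated chain carbon, four bonds along the chain from a nitrogen on an aromatic ring. Nothing here offers an account of why these numbers stay together.

Going by these compounds, it remains open whether any other end group at this place would leave the scatter in this assay, for instance a primary amine, a piperidine, a morpholine or a carboxylic acid. On these data alone, it also remains open whether a longer chain carrying the same ethyl(methyl)amino would give a number that can be separated from those of the three compounds in hand.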